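A few compounds are considered here, and "the series" means these few. Any claim that something is new, unique, unknown or untested is made for them only; others in the source may bear on it.

Measured so far in a functional assay on MGC-803 cells (Homo sapiens) for antiproliferative activity, read by MTT assay; on this read-out higher numbers stand for weaker inhibition and lower numbers for stronger inhibition:
- compound 1 `Cc1ccccc1NC(=O)Nc1cccc(CNc2ncnc3ccccc23)c1` gives > 50000 nM, which is a limit of this assay and not a number
- compound 2 `Cc1cccc(NC(=O)Nc2cccc(CNc3ncnc4ccccc34)c2)c1` gives 30200 nM
- compound 3 `Cc1ccc(NC(=O)Nc2cccc(CNc3ncnc4ccccc34)c2)cc1` gives 31200 nM

Compound 3 stands with the highest of the two numbers shown, but its nearest neighbour is compound 2, and a 1.0-fold higher number from compound 2 to compound 3 (0.01 log units; within the scatter), so the two cannot be told apart. Compound 1 contributes only a limit, as noted in the limit of > 50000 nM in this assay, at which 1 of the 3 values shown sits.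

The next compound, compound 4 `COc1ccccc1NC(=O)Nc1cccc(CNc2ncnc3ccccc23)c1`, differs from compound 3 in one place: 2-methoxyphenyl in place of 4-methylphenyl on an amide-type nitrogen.

For the measured compounds named here, two measured steps bear on this change. The step of an at least 1.6-fold lower number from compound 1 to compound 3 (0.20 log units; that floor lies within the scatter) shows that moving the methyl from the 2-methylphenyl to the 4-methylphenyl lowered the number at least to the floor of the assay range; the step of an at least 1.6-fold lower number from compound 1 to compound 2 (0.21 log units; that floor lies within the scatter) shows the same for the 3-methylphenyl. Compound 4 carries 2-methoxyphenyl, a group whose name opens as that of the 2-methylphenyl of compound 1 does, now carrying a methoxy in place of a methyl, so the more likely direction is a higher number in this assay, possibly back at the limit, though the step of an at least 1.6-fold lower number from compound 1 to compound 3 (0.20 log units; that floor lies within the scatter) is itself within the scatter and so the expectation is weak.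

Compound 4 is therefore expected to give 45000 nM, within 20000 nM to 100000 nM, that is an estimated step of a 1.4-fold higher number from compound 3 to compound 4 (0.16 log units; within the scatter).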

Compound 4, half-maximal inhibitory concentration: 39300 nM
For compound 4 the middle estimate is 1.1-fold (0.06 log units) above the measured one, and the stated range covers the measured number.
By their numbers in this assay, from the lowest: compounds 2, 3 and 4 (each within the scatter of the next). At a limit, above all of these: compound 1.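

In this assay, 2-methoxyphenyl on the amide-type nitrogen cannot be told apart from either of the other two groups that give a number: a 1.3-fold higher number from compound 3 to compound 4 (0.10 log units; within the scatter), and a 1.3-fold higher number from compound 2 to compound 4 (0.11 log units; within the scatter). Methoxy in place of methyl on an aromatic carbon gives an at least 1.2-fold lower number from compound 1 to compound 4 (0.10 log units; that floor lies within the scatter), so compound 4 returns a number where its closest relative does not, but the floor of that step is too small to show a real difference between the two groups. Compound 1 is now the only one of the series that remains at a limit, which is not a number: the limit of > 50000 nM in this assay, at which 1 of the 4 values shown sits.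

The compounds shown therefore leave open whether any group on this phenyl ring can move the number beyond the scatter, since methyl and methoxy give values that cannot be separated and no step here is shown to exceed it. From the compounds shown here alone, how a carboxylic acid, an amine or a trifluoromethyl in place of the methyl or methoxy would read in this assay stays unknown, as does any effect of changing the shared core rather than this ring.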